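The source may report more compounds than this note shows. Statements on the series, on what has been measured and on what is new or still open speak of the compounds shown alone.

Measured so far:
- compound 1, `N=C(N)NCCC[C@@H]1NC(=O)c2ccc(cc2)-c2cccc3c(c[nH]c23)C[C@@H](C(N)=O)NC(=O)[C@@H](Cc2ccccc2)NC(=O)[C@H](CC(=O)O)NC(=O)CNC1=O`: 5670 nM
- compound 2, `N=C(N)NCCC[C@@H]1NC(=O)c2cccc(c2)-c2cccc3c(c[nH]c23)C[C@@H](C(N)=O)NC(=O)[C@H](CC(=O)O)NC(=O)CNC1=O`: 8030 nM

Two macrocycles have been measured in an assay on a protein complex for binding affinity to integrin alpha-5/beta-1 (Homo sapiens), read by ELISA, with a stated time of 1 h; a higher number here means a weaker inhibitor, a lower number a stronger inhibitor. Compound 1 gives 5670 nM in this assay. Compound 2 gives 8030 nM in this assay; the two numbers lie within the usual scatter of each other, so no order between compound 1 and compound 2 can be read from them.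

The next compound, compound 3 `N=C(N)NCCC[C@@H]1NC(=O)c2ccc(cc2)-c2cccc3c(c[nH]c23)C[C@H](C(N)=O)NC(=O)[C@H](Cc2ccccc2)NC(=O)[C@H](CC(=O)O)NC(=O)CNC1=O`, keeps every atom and bond of compound 1; the change is the two compounds have the same atoms and bonds; at least one stereo element is drawn with a configuration in one of them and without one in the other: 2 of 5 stereo elements differ; a stereocentre at a saturated ring carbon is drawn S in compound 1 and R in compound 3; a stereocentre at a saturated ring carbon is drawn R in compound 1 and S in compound 3. Among the compounds with values here, no step between two measured compounds involving an inversion of this kind is available, so the size and direction of the step cannot be derived from the measured pair. Inverting two ring stereocentres in a macrocycle of this type is expected to move the number, but the direction is open; a wide band is therefore assumed.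

Compound 3 is estimated at 9000 nM in this assay, within 2000 nM to 40000 nM, an expected step of a 1.6-fold higher number from compound 1 to compound 3 (0.20 log units; within the scatter).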

Compound 3, half-maximal inhibitory concentration: 9290 nM
For compound 3 the middle estimate is 1.0-fold (0.01 log units) below the measured one; the measured number falls inside the stated range.
By their numbers in this assay, from the lowest: compounds 1, 2 and 3 (each within the scatter of the next).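

Within the data shown here, this pair gives the first step at these two ring stereocentres: inverting both together gives a 1.6-fold higher number from compound 1 to compound 3 (0.21 log units; within the scatter) in this assay. Compound 1 and compound 3 share every atom and bond, so the comparison concerns configuration alone, and with both centres inverted at once, no change can be read at this level of binding. Nothing on record for this pair accounts for the step.

Going by these compounds, whether inverting only one of the two stereocentres gives a similar reading stays open, as both change together in this pair. Also open, on these data alone, is how the number in this assay would respond if a primary amine or a tetrazole were carried on the core of compound 1.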